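This account rests on a few compounds, and the source may have more. Where it says the series, first, only, none or still open, it means among the compounds named here.

Compound 3, `O=C1C(N2CCCC2)=CC(=O)c2c1nc1n2[C@H]2OC[C@@H](O)[C@H]2OC1`, carries a pyrrolidin-1-yl group on a double-bonded ring carbon of the shared core. In a functional assay on MCF7 cells (Homo sapiens) for inhibition, read by sulforhodamine B assay (on this read-out lower numbers stand for stronger inhibition and higher numbers for weaker inhibition), compound 3 gives only a limit of the assay, > 16000 nM, so its standing on the numbers is known merely as the weakest end of the set, as noted in the limit of > 16000 nM in this assay, at which 1 of the 3 values shown sits. The measured relatives with an amino substituent at that carbon fare better: compound 1, `Cc1ccc(NC2=CC(=O)c3c(nc4n3[C@H]3OC[C@@H](O)[C@H]3OC4)C2=O)cc1C`, gives 4950 nM in this assay, and compound 2, `CCc1ccc(NC2=CC(=O)c3nc4n(c3C2=O)[C@H]2OC[C@@H](O)[C@H]2OC4)cc1`, gives 960 nM. Among the compounds with values here, the one measured step that touches the position, an at least 3.2-fold higher number from compound 1 to compound 3 (0.50 log units; beyond the scatter), shows that swapping a (3,4-dimethylphenyl)amino group for pyrrolidin-1-yl costs potency beyond the scatter.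

Compound 4, `O=C1C(NC2CCCCC2)=CC(=O)c2c1nc1n2[C@H]2OC[C@@H](O)[C@H]2OC1`, is not yet measured. It differs from compound 3 as follows: cyclohexylamino in place of pyrrolidin-1-yl on a double-bonded ring carbon. The change restores a hydrogen-bond donor, though with a saturated ring in place of the aryl rings of compound 1 and compound 2. On that basis the step from compound 3 to compound 4 in this assay is expected to run toward a lower number, about an at least 1.7-fold lower number from compound 3 to compound 4 (0.24 log units; that floor lies within the scatter), but with wide uncertainty since compound 3 itself is a limit. Compound 4 is therefore estimated at 9000 nM, within a range from 2500 nM to 35000 nM.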

Compound 4, half-maximal inhibitory concentration: > 16000 nM
Compound 4: a limit, no number (the forecaster's own chance of this, stated with the estimate: 35%); at least 1.7-fold (0.24 log units) between middle value and limit.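

Bringing back an amino nitrogen with its hydrogen-bond donor does not by itself keep the activity in this assay: with cyclohexyl in place of 3,4-dimethylphenyl on the amine nitrogen, the record shows an at least 3.2-fold higher number from compound 1 to compound 4 (0.50 log units; beyond the scatter). Up to this point, compound 3 differed from compound 1 in both the amine hydrogen and the aromatic ring, so the two could not be told apart; compound 4 keeps the donor and gives up the aromatic ring, and it still ends at a limit of the assay rather than at a number. The step between compound 3 and compound 4 cannot be read, and no order can be stated for pyrrolidin-1-yl and cyclohexylamino, as both values are limits: the limit of > 16000 nM in this assay, at which 2 of the 4 values shown sit.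

The compounds shown leave open whether the nitrogen is needed at all once an aromatic ring is present, as a phenoxy group or a benzylamino group on this carbon would test. They also leave open how the aromatic ring of compound 1 and compound 2 would respond to a methoxy group or a chlorine atom in place of their alkyl groups.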